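Chloro in Place of Methoxy: Cytotoxicity Expected Unchanged

The source may hold more compounds than are shown below. What is called first, only, known or untested is meant among the compounds shown, and "the series" means these compounds.

Compound 3 `COc1ccc(CSc2nnc(-c3cc([N+](=O)[O-])cc(C(F)(F)F)c3)n2Cc2ccccc2)cc1` is the point of departure. In an ADME assay on HepG2 cells (Homo sapiens) for cytotoxicity, with a stated time of 48 h (a higher number here means a weaker inhibitor, a lower number a stronger inhibitor), compound 3 gives > 30000 nM, a value that is a limit of the assay and not a number. Two related compounds share this standing. Compound 1 `COc1ccc(CSc2nnc(-c3cc([N+](=O)[O-])cc([N+](=O)[O-])c3)n2Cc2ccccc2)cc1` gives > 30000 nM in this assay, again a limit. Compound 2 `O=[N+]([O-])c1cc(-c2nnc(SCc3ccc(Cl)cc3)n2Cc2ccccc2)cc([N+](=O)[O-])c1` gives > 30000 nM in this assay, also a limit. The picture is therefore (the limit of > 30000 nM in this assay, at which 3 of the 3 values shown sit), and the steps among these compounds cannot be read: the step that the two limits leave unreadable from compound 1 to compound 2 and the step that the two limits leave unreadable from compound 1 to compound 3 are both hidden by the limits.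

Compound 4 `O=[N+]([O-])c1cc(-c2nnc(SCc3ccc(Cl)cc3)n2Cc2ccccc2)cc(C(F)(F)F)c1` is not yet measured. It differs from compound 3 in one place: chloro in place of methoxy on an aromatic carbon. Going by the values given here, the same change, chloro in place of methoxy on an aromatic carbon, is the one taken from compound 1 to compound 2, where the two limits leave its size unreadable. Among the compounds with values here, nothing among the measured values speaks for a move into readable territory, so for compound 4 the expected step is a step that the limit leaves unreadable from compound 3 to compound 4, nothing beyond the scatter. Compound 4 is accordingly estimated at 40000 nM in this assay, within a range from 15000 nM to 120000 nM, and is most likely to be reported once more only as a limit.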

Compound 4, half-maximal inhibitory concentration: > 30000 nM
Compound 4: no number, only a limit; the forecaster's own chance of this, stated with the estimate: 85%; the middle value does not contradict the limit.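

Compound 4 sits at a limit of this assay, as do compound 1, compound 2 and compound 3, so neither new step, from compound 3 or from compound 2 to compound 4, can be read: the limit of > 30000 nM in this assay, at which 4 of the 4 values shown sit.

The compounds shown leave open how large the change from methoxy to chloro, or from nitro to trifluoromethyl, actually is in this series.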